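Swapping an amine for an amide on the outer ring

The compounds below may be only part of what the source reports. "The series", "measured", "known", "first", "only" and "open" are said of these compounds alone.

Measured so far:
- compound 1, `CCNC(=O)c1noc(-c2cc(C(C)C)c(O)cc2O)c1-c1cc(CNC(C)C)no1`: 38 nM
- compound 2, `CCNC(=O)c1noc(-c2cc(C(C)C)c(O)cc2O)c1-c1cc(CN(C)C)no1`: 31 nM

In a functional assay on A2780 cells (Homo sapiens) for inhibition (a lower number here means a stronger inhibitor, a higher number a weaker inhibitor), compound 2 holds the lowest of the two numbers, with compound 1 next to it at a step that is within the scatter, a 1.2-fold lower number from compound 1 to compound 2 (0.09 log units; within the scatter). Compound 3, `CCNC(=O)c1noc(-c2cc(C(C)C)c(O)cc2O)c1-c1cc(C(=O)NC)no1`, differs from compound 2 in one place: methylcarbamoyl in place of (dimethylamino)methyl on an aromatic carbon. Going by the values given here, the only measured step alters the amine on the chain, not its exchange for an amide, so no measured step bears on this change and no direction can be read from the numbers. The expected step from compound 2 to compound 3 is therefore wide, a 1.9-fold higher number from compound 2 to compound 3 (0.29 log units; within the scatter). Compound 3 is estimated at 60 nM, between 15 nM and 250 nM.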

Compound 3, half-maximal inhibitory concentration: 100 nM
Compound 3: the middle estimate sits 1.7-fold (0.22 log units) below what was measured; the measured number falls inside the stated range.
By their numbers in this assay, from the lowest: compounds 2 and 1 (each within the scatter of the next); then compound 3.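

On this aromatic carbon the amines of compound 1 and compound 2 sit within the scatter of each other, but methylcarbamoyl does not replace them without cost. In this assay there is a 3.2-fold higher number from compound 2 to compound 3 (0.51 log units; beyond the scatter) and a 2.6-fold higher number from compound 1 to compound 3 (0.42 log units; beyond the scatter) for the exchange, so the position does respond to the group it carries, if only modestly. Nothing measured here explains this step. From the compounds shown here alone, it stays open whether the loss of the amine or the arrival of the amide matters more. A carboxylic acid or a longer amide chain on this carbon could help separate the two.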